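From 3-fluorophenyl to 2-hydroxyphenyl on compound 1

A few compounds are considered here, and "the series" means these few. Any claim that something is new, unique, unknown or untested is made for them only; others in the source may bear on it.

In a functional assay on MCF7 cells (Homo sapiens) for inhibition, with a stated time of 72 h (a lower number here means a stronger inhibitor, a higher number a weaker inhibitor), compound 1 (`NC1CCC(Nc2nc(NCc3ccc(-c4cccc(F)c4)cc3)c3ncn(C4CCCC4)c3n2)CC1`) gives 293 nM as its reading. Two relatives frame it. Compound 3 (`NC1CCC(Nc2nc(NCc3ccc(-c4ccsc4)nc3)c3ncn(C4CCCC4)c3n2)CC1`) reads 100 nM as the lowest number of the group, and compound 2 (`CC(C)(O)CNc1nc(NCc2ccc(-c3ccco3)cc2)c2ncn(C3CCCC3)c2n1`) reads 15300 nM as the highest. Compound 1 therefore stands second highest of the three, nearer to compound 3 than to compound 2, and both gaps lie beyond the usual scatter. No two of these measured compounds differ in one place alone, so none of them offers a direct step to reason from.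

The next compound is compound 4 (`NC1CCC(Nc2nc(NCc3ccc(-c4ccccc4O)cc3)c3ncn(C4CCCC4)c3n2)CC1`), which keeps the rest of compound 1 and carries 2-hydroxyphenyl in place of 3-fluorophenyl on an aromatic carbon. The swap sits para to a large group. Among the measured compounds shown here, the data hold no measured step for a swap of this kind, so the closest anchor is compound 1 at 293 nM in the same test. On these data alone, no step beyond the scatter is expected in this assay here, and either direction stays open. The estimated change is a 1.2-fold lower number from compound 1 to compound 4 (0.07 log units; within the scatter) as a central guess. Compound 4 is expected at 250 nM as a middle value, with an estimated range from 70 nM to 900 nM in this test.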

Compound 4, half-maximal inhibitory concentration: 2910 nM
Beside the measured number, compound 4's estimate is 12-fold (1.07 log units) below it; measured number outside the range, above it.
By their numbers in this assay, from the lowest: compound 3; then compound 1; then compound 4; then compound 2.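

Among the compounds shown here, compound 4 supplies the first step that can be read directly, and it shows that the aryl group para to a large group is not a neutral place for change: in this assay, replacing 3-fluorophenyl with 2-hydroxyphenyl gives a 9.9-fold higher number from compound 1 to compound 4 (1.00 log units; beyond the scatter), a step beyond the scatter. The two groups are closely matched in what is counted, since each has 7 heavy atoms and one six-membered aromatic ring of carbon only, so this sizeable loss comes from a change that leaves the size of the group as counted untouched. The swap alters two things at once: the fluorine gives way to a hydroxyl, and the substituent's place on the ring moves as well. This single step cannot divide the loss between the two.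

Compounds such as the 3-hydroxyphenyl or 2-fluorophenyl analogues, or the 2-methoxyphenyl analogue, would pull those two changes apart, and the compounds shown leave all of these open. No measurement bearing on the cause of the rise is given here.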